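Aryl amine swap on the shared core: expectation for compound 3

This account rests on a few compounds, and the source may have more. Where it says the series, first, only, none or still open, it means among the compounds named here.

Measured so far:
compound 1, `Cc1ccc(-c2nc(SCc3cn(CC(=O)NC(=O)Nc4ccccn4)nn3)nc(Nc3ccc(C(C)C)cc3)c2C#N)cc1` — 35 nM
compound 2, `COc1ccccc1Nc1nc(SCc2cn(CC(=O)NC(=O)Nc3ccccn3)nn2)nc(-c2ccc(C)cc2)c1C#N` — 8580 nM

In a functional assay on B16-F10 cells (Mus musculus) for inhibition, read by MTT assay, with a stated time of 72 h (a lower number here means a stronger inhibitor, a higher number a weaker inhibitor), compound 2 stands highest of the two numbers at hand; its nearest neighbour, compound 1, gives 35 nM. Within the data shown here, the single measured step at this position, a 250-fold higher number from compound 1 to compound 2 (2.39 log units; beyond the scatter), is large and beyond the scatter.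

Compound 3, `Cc1ccc(Nc2nc(SCc3cn(CC(=O)NC(=O)Nc4ccccn4)nn3)nc(-c3ccc(C)cc3)c2C#N)cc1`, has not been measured. It differs from compound 2 by 4-methylphenyl in place of 2-methoxyphenyl on a nitrogen on an aromatic ring. Among the measured compounds shown here, the only step that bears on it is a 250-fold higher number from compound 1 to compound 2 (2.39 log units; beyond the scatter), which runs the other way: the 4-isopropylphenyl of compound 1 gave the far lower number, and compound 3 brings in a 4-methylphenyl, also an aryl group carrying an alkyl substituent and no hydrogen-bond acceptor. For the measured compounds named here, a large downward step is therefore expected in this assay, though not necessarily the full size seen between compound 1 and compound 2, since only one such step is known. The expected step is a 57-fold lower number from compound 2 to compound 3 (1.76 log units; beyond the scatter); compound 3 is estimated at 150 nM, within 35 nM to 900 nM.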

Compound 3, half-maximal inhibitory concentration: 1010 nM
Estimate against measurement, compound 3: 6.7-fold (0.83 log units) below; the whole stated range lies below it.
By their numbers in this assay, from the lowest: compound 1; then compound 3; then compound 2.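

In this assay, the aryl group on the nitrogen does more than separate compound 1 from compound 2: replacing 2-methoxyphenyl with 4-methylphenyl gives an 8.5-fold lower number from compound 2 to compound 3 (0.93 log units; beyond the scatter), a modest step. The alkyl group on the aromatic carbon also matters, since methyl in place of isopropyl gives a 29-fold higher number from compound 1 to compound 3 (1.46 log units; beyond the scatter), a large step, so a 4-alkylphenyl group alone does not secure the number of compound 1. No supporting measurement accounts for either step.

The step from compound 2 to compound 3 changes both the substituent and its place on the phenyl ring, so 4-methoxyphenyl would be needed to separate the two changes. On these data alone, how the number tracks the alkyl group between and beyond methyl and isopropyl remains open, with ethyl and tert-butyl as the next groups of interest.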